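Notes on the shared core: substitution on the amine nitrogen

The compounds below may be only part of what the source reports. "The series", "measured", "known", "first", "only" and "open" are said of these compounds alone.

Measured compounds:
- compound 1, `CCOC(=O)C1=C(N/N=C(/C#N)C(=O)OCC)Nc2[nH]nc(C)c2C1c1ccc(N(C)C)cc1`: 39200 nM
- compound 2, `CCOC(=O)C1=C(NN=C(C#N)C#N)Nc2[nH]nc(C)c2C1c1ccc(N(C)C)cc1`: 15200 nM
- compound 3, `CCOC(=O)C1=C(N/N=C(/Cl)C#N)Nc2[nH]nc(C)c2C1c1ccc(N(C)C)cc1`: 26200 nM

In a functional assay on HeLa cells (Homo sapiens) for inhibition, read by MTT assay, with a stated time of 48 h (on this read-out lower numbers stand for stronger inhibition and higher numbers for weaker inhibition), compound 1 gives the highest of the three numbers. The two measured steps both leave compound 1 and both exchange the group on the amine nitrogen for a smaller one without a ring: a 2.6-fold lower number from compound 1 to compound 2 (0.41 log units; beyond the scatter), a modest step beyond the scatter, and a 1.5-fold lower number from compound 1 to compound 3 (0.17 log units; within the scatter), within the scatter. Between the two smaller groups themselves, a 1.7-fold higher number from compound 2 to compound 3 (0.24 log units; within the scatter), again within the scatter.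

Compound 4, `CCOC(=O)C1=C(N/C=N/c2ccc([N+](=O)[O-])cc2)Nc2[nH]nc(C)c2C1c1ccc(N(C)C)cc1`, has not yet been measured in this assay. It differs from compound 1 at the same amine nitrogen: a group of 11 heavy atoms (7 carbon, 2 nitrogen, 2 oxygen; one six-membered aromatic ring of carbon only) in place of a group of 9 heavy atoms (5 carbon, 2 nitrogen, 2 oxygen; no ring), on an amine nitrogen. Among the compounds with values here, this change goes the other way from the measured steps, to a larger group that brings in a six-membered aromatic ring of carbon only, and no measured pair covers a change of that kind. The steps that do bear on it are small, so no step beyond the scatter is expected in this assay from compound 1 to compound 4, with a wide range around that expectation.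

For compound 4 the expected value is 30000 nM, between 10000 nM and 90000 nM, which means an expected step of a 1.3-fold lower number from compound 1 to compound 4 (0.12 log units; within the scatter).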

Compound 4, half-maximal inhibitory concentration: 57800 nM
For compound 4 the middle estimate is 1.9-fold (0.28 log units) below the measured one; the range from low to high includes it.
By their numbers in this assay, from the lowest: compounds 2, 3, 1 and 4 (each within the scatter of the next, the first and the last beyond it).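

In this assay, within the data shown here, the group with one six-membered aromatic ring of carbon only is the first ring-bearing group seen on this amine nitrogen, and it reads no differently from the open-chain group of 9 heavy atoms (a 1.5-fold higher number from compound 1 to compound 4 (0.17 log units; within the scatter)). Against the two smaller open-chain groups it does separate, with a 2.2-fold higher number from compound 3 to compound 4 (0.34 log units; beyond the scatter) and a 3.8-fold higher number from compound 2 to compound 4 (0.58 log units; beyond the scatter), so the spread at this position now goes beyond the scatter at both smaller groups, while the pattern of smaller groups giving lower numbers is not clean: compound 1 stays within the scatter of both compound 3 and compound 4. Nothing measured here accounts for these steps.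

Compound 4 changes size and adds the ring in a single step, so the four compounds cannot show whether either one alone sets its number. Also open, as far as these compounds go, is how this position responds to a group of another kind, such as a basic amine, a carboxylic acid or a longer open alkyl chain on the same nitrogen.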